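The source may hold more compounds than are shown below. What is called first, only, known or untested is meant among the compounds shown, and "the series" means these compounds.

Compound 1 `CCOC(=O)N1CCC(Oc2cc(Oc3ccc(/C=C4\SC(=O)NC4=O)cc3)ncn2)CC1` gives 51.8% in a functional assay on CHO-K1 cells for agonist activity at Glucose-dependent insulinotropic receptor (Homo sapiens), read by cAMP accumulation and immunoassay, with a stated time of 1 h; a lower number here means a smaller maximal response, a higher number a larger maximal response.
Compound 2 `CC(C)(C)OC(=O)N1CCC(Oc2cc(Oc3ccc(/C=C4\SC(=O)NC4=O)cc3)ncn2)CC1` gives 122% in this assay.

Compound 2 stands highest of the two numbers in this assay; its nearest neighbour is compound 1, and the step between them, a number 70.2 percentage points higher from compound 1 to compound 2 (beyond the scatter), is large and beyond the scatter. Compound 3 `CC(C)COC(=O)N1CCC(Oc2cc(Oc3ccc(/C=C4\SC(=O)NC4=O)cc3)ncn2)CC1` has not been measured. It differs from compound 2 in one place: isobutyl in place of tert-butyl on an oxygen next to a carbonyl group. Among the compounds with values here, the only measured step that bears on this change is a number 70.2 percentage points higher from compound 1 to compound 2 (beyond the scatter), which shows that exchanging a smaller group for tert-butyl on the oxygen next to the carbonyl group raised the maximal response markedly. The present change keeps the count of four carbons in the group but alters their arrangement, a change not covered by any measured pair, so the direction and size of the step must be inferred from that single comparison. Compound 3 is expected to sit between the two measured values, nearer to compound 2, with a step of a number 22 percentage points lower from compound 2 to compound 3 (beyond the scatter) that may fall within the scatter. Compound 3 is therefore estimated at 100%, within a range of 60% to 130%.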

Compound 3, largest response reached (Emax), in percent of the reference or control that the assay uses: 51%
The estimate for compound 3 lay 49 percentage points above the measured number; measured number below the stated range.
By their numbers in this assay, from the lowest: compounds 3 and 1 (each within the scatter of the next); then compound 2.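

In this assay the large response of compound 2 does not follow from the size of the group on the oxygen next to a carbonyl group: tert-butyl and isobutyl have the same heavy-atom count and differ only in how their carbons are joined, yet the result is a number 71 percentage points lower from compound 2 to compound 3 (beyond the scatter) and the step is large. Isobutyl also fails to separate from ethyl, with a number 0.8 percentage points lower from compound 1 to compound 3 (within the scatter), so compound 1 and compound 3 cannot be told apart in this assay and, of the three compounds, only the tert-butyl of compound 2 stands apart. No measurement is available that would explain why these two arrangements of the same carbons give such different maximal responses.

The compounds shown leave open whether the large response belongs to tert-butyl alone or extends to other branched groups in this place, such as isopropyl, tert-pentyl or neopentyl. They also leave open how a cyclobutyl group or a longer straight chain on the same oxygen would compare with compound 2 and compound 3.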